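The source may report more compounds than this note shows. Statements on the series, on what has been measured and on what is new or still open speak of the compounds shown alone.

Measured so far in a functional assay on T47D cells (Homo sapiens) for cytotoxicity, with a stated time of 72 h, tested at 50 ug/mL; a lower number here means a weaker effect, a higher number a stronger effect of the compound at the concentration tested:
compound 1 `Cc1ccc(N2CCn3c2n[nH]c(=O)c3=O)cc1` gives 22%
compound 2 `N/N=C1\NCCN1c1ccccc1Cl` gives 27%
compound 3 `COc1ccccc1N1CCn2c1n[nH]c(=O)c2=O` gives 9%

Compound 2 holds the highest of the three numbers in this assay. Its nearest neighbour is compound 1, whose number lies within the usual scatter of that of compound 2, so no order between these two can be read from the values. Compound 3 sits beyond the scatter below compound 2, so for this pair a real difference is shown; the two differ in core as well as substituent, and the gap is noted only as a pair of values.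

The next compound, compound 4 `N/N=C1\NCCN1c1ccccc1`, not yet measured in this assay, comes from compound 2 by the change (hydrogen in place of chloro on an aromatic carbon). Going by the values given here, no step of this kind exists among the measured compounds, so there is nothing to calibrate its size against. The expectation is a modest move in this assay, more likely downward than upward, or none beyond the scatter.

For compound 4 the estimate in this assay is 20%, with a range from 5% to 38%. The step this estimate means, a number 7 percentage points lower from compound 2 to compound 4 (within the scatter), is expected to fall within or only just beyond the scatter.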

Compound 4, a percentage reported as inhibition, at one concentration (the size of the read-out at that concentration, not a potency): 0%
Compound 4: the middle estimate sits 20 percentage points above what was measured; measured number outside the range, below it.
By their numbers in this assay, from the lowest: compounds 4 and 3 (each within the scatter of the next); then compounds 1 and 2 (each within the scatter of the next).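

In this assay, hydrogen in place of chloro on an aromatic carbon, ortho to a group of 7 heavy atoms, comes with a number 27 percentage points lower from compound 2 to compound 4 (beyond the scatter) in this pair. Going by these compounds alone, this is the first step that differs in one place only, and it shows that the read-out at this concentration is sensitive to what stands on this carbon: compound 2 gives 27% with chloro and compound 4 gives 0% with hydrogen, so in this pair the measurable effect is present only with the chloro. Nothing available on these compounds accounts for a step of this size from the loss of a single chlorine atom.

Still open, on these data alone, is whether chloro itself matters or whether other groups on this carbon, such as bromo, an amine or a carboxylic acid, would also keep a number above that of compound 4. Also open, as far as these compounds go, is whether the same change would carry a step of similar size on another carbon of this ring, or on the aromatic ring attached to the different core shared by compound 1 and compound 3.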